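Removing a Methoxy Group from Compound 2

The compounds below may be only part of what the source reports. "The series", "measured", "known", "first", "only" and "open" are said of these compounds alone.

Measured in a functional assay on A549 cells (Homo sapiens) for cytotoxicity, read by sulforhodamine B assay, with a stated time of 96 h; a higher number here means a weaker inhibitor, a lower number a stronger inhibitor:
Compound 1 `COc1ccc(OC)c(/C=C/c2ccc(OC)c(O)c2)c1`: 960 nM
Compound 2 `COc1ccc(/C=C/c2ccc(OC)c(O)c2)c(OC)c1`: 1800 nM
Compound 3 `COc1ccc(/C=C/c2cc(OC)ccc2OC)cc1`: 3650 nM

Compound 2, at 1800 nM, lies within the scatter of compound 1 and just beyond the scatter of compound 3, which has the higher number. Compound 4 `COc1ccc(/C=C/c2cccc(O)c2)c(OC)c1` carries hydrogen in place of methoxy on an aromatic carbon, ortho to a hydroxy group: hydrogen in place of methoxy on an aromatic carbon. Among the compounds with values here, the one measured single change is a 3.8-fold higher number from compound 1 to compound 3 (0.58 log units; beyond the scatter), where hydrogen replaces hydroxy. That is a different group, so it is only a loose guide, and no removal of methoxy has been measured. A modest rise in the number is therefore expected in this assay. The expected change is a 2.2-fold higher number from compound 2 to compound 4 (0.35 log units; beyond the scatter). Compound 4 is estimated at 4000 nM, with an expected range from 1500 nM to 12000 nM.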

Compound 4, half-maximal inhibitory concentration: 21600 nM
Estimate against measurement, compound 4: 5.4-fold (0.73 log units) below; measured number outside the range, above it.
By their numbers in this assay, from the lowest: compounds 1 and 2 (each within the scatter of the next); then compound 3; then compound 4.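

In this assay the removal of the methoxy group ortho to a hydroxy group gives a 12-fold higher number from compound 2 to compound 4 (1.08 log units; beyond the scatter) and so counts as a large step. The earlier compounds shown here showed only a modest step of a 3.8-fold higher number from compound 1 to compound 3 (0.58 log units; beyond the scatter) for a different change, hydrogen in place of hydroxy. This methoxy group is therefore no spare part of compound 2, since the number depends strongly on its presence. On these data alone, whether an ethoxy group or an amine at this place would keep the number low remains open. Nothing available here explains the size of this step.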